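Swapping Isopropyl for Difluoromethyl on the Furan

A few compounds are considered here, and "the series" means these few. Any claim that something is new, unique, unknown or untested is made for them only; others in the source may bear on it.

Three compounds of a shared core have been measured in an assay on CHO-K1 cells for antagonist activity at adenosine receptor A1 (Homo sapiens), read by a beta-galactosidase reporter, with stated times of 15 min and 6 h; a lower number here means a stronger inhibitor, a higher number a weaker inhibitor:

Compound 1 `CN(C)Cc1cc2c(N)nc(-c3ccco3)nc2s1` gives 3550 nM.
Compound 2 `Nc1nc(-c2ccco2)nc2sc(CN3CCC(=O)CC3)cc12` gives 2720 nM.
Compound 3 `CC(C)c1ccc(-c2nc(N)c3cc(CN4[C@H](C)CCC[C@@H]4C)sc3n2)o1` gives 140 nM.

Compound 3 stands lowest of the three, and both other compounds lie beyond the usual scatter above it, so it is the strongest inhibitor in this set. Compound 4 `C[C@@H]1CCC[C@H](C)N1Cc1cc2c(N)nc(-c3ccc(C(F)F)o3)nc2s1` has not yet been measured in this assay. It differs from compound 3 in one place: difluoromethyl in place of isopropyl on an aromatic carbon.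

Within the data shown here, only one measured step exists between neighbouring compounds, a 1.3-fold lower number from compound 1 to compound 2 (0.12 log units; within the scatter), and it changes the amine on the saturated chain carbon, not the furan. Among the measured compounds shown here, no measured pair changes the group on the furan, so the data give no direct guide to the size or direction of the step to compound 4. The isopropyl and difluoromethyl groups match in heavy-atom count and in donors and acceptors, so a modest change is the plainest expectation, with the direction open.

Compound 4 is therefore expected to read around 280 nM, within a range from 70 nM to 1100 nM, which means an expected step of a 2.0-fold higher number from compound 3 to compound 4 (0.30 log units; within the scatter).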

Compound 4, inhibition constant: 730 nM
Estimate against measurement, compound 4: 2.6-fold (0.42 log units) below; the range from low to high includes it.
By their numbers in this assay, from the lowest: compound 3; then compound 4; then compounds 2 and 1 (each within the scatter of the next).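

The group on the furan turns out not to be a neutral place in the molecule: in this assay, the swap gives a 5.2-fold higher number from compound 3 to compound 4 (0.72 log units; beyond the scatter), so difluoromethyl in place of isopropyl leaves a weaker inhibitor by more than the usual scatter of repeat measurements. Among these compounds, this is the first measured change at this place, as the only earlier step altered the amine on the other side of the shared core. The two groups match in heavy-atom count, carry no hydrogen-bond donors or acceptors and have no net charge, yet they read differently, so these simple counts do not settle the result here, and nothing measured in this set explains the difference.

A single pair cannot show how other groups at this place would read, such as a methyl, a tert-butyl or a trifluoromethyl group. On these data alone, it also remains open whether the same swap would give a step of similar size and direction if the amine of compound 3 were replaced by the dimethylamino group of compound 1 or the 4-oxopiperidin-1-yl group of compound 2.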